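The compounds below may be only part of what the source reports. "The series", "measured", "known", "first", "only" and "open" are said of these compounds alone.

Triazene series in an ADME assay on Vero cells (Chlorocebus sabaeus) for cytotoxicity, read by crystal violet staining; on this read-out lower numbers stand for higher toxicity in this test and higher numbers for lower toxicity in this test. Compound 1 `FC(F)(F)c1cccc(/N=N/N2CCCC2)c1` gives a limit of the assay, > 100000 nM, in this assay. Compound 3 `c1ccc(/N=N/N2CCCC2)cc1` likewise gives a limit of the assay, > 100000 nM. The change hydrogen in place of trifluoromethyl on an aromatic carbon thus yields a step that the two limits leave unreadable from compound 1 to compound 3, which rests on (the limit of > 100000 nM in this assay, at which 2 of the 3 values shown sit). Among the measured compounds shown here, compound 2 `CN(C)CCCN(/N=N/c1ccccc1)c1cccc(C(F)(F)F)c1` gives 20000 nM in this assay, the only number among the three measured values. The difference between the cores of compound 1 and compound 2 is not broken down here. Compound 4 `CN(C)CCCN(/N=N/c1ccccc1)c1ccccc1` carries the same kind of change applied to compound 2, (hydrogen in place of trifluoromethyl on an aromatic carbon); around the place, the neighbouring group is described as a large group rather than a group of 7 heavy atoms. For compound 4 a step near zero, a 1.3-fold higher number from compound 2 to compound 4 (0.10 log units; within the scatter), is expected, because a step that the two limits leave unreadable from compound 1 to compound 3 offers no readable direction for this change. Compound 4 is estimated at 25000 nM, between 8000 nM and 90000 nM.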

Compound 4, half-maximal cytotoxic concentration: 35000 nM
For compound 4 the middle estimate is 1.4-fold (0.15 log units) below the measured one, and the stated range covers the measured number.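

In this assay, hydrogen in place of trifluoromethyl gives a 1.8-fold higher number from compound 2 to compound 4 (0.24 log units; within the scatter), so the two compounds cannot be told apart on the core of compound 2. This is a single pair on a single core and shows no general behaviour of the change across the series. The same change on the core of compound 1 cannot be read, which leaves no comparison between the two cores and no evidence on whether the result carries over: the limit of > 100000 nM in this assay, at which 2 of the 4 values shown sit.

Open, on these data alone, is how a nitrile, a methoxy group or a carboxylic acid would read at this place on the aromatic ring. Also open, as far as these compounds go, is the effect of a longer chain carrying the amine on the core of compound 2.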